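Bromo in place of hydrogen on compound 1

A few compounds are considered here, and "the series" means these few. Any claim that something is new, unique, unknown or untested is made for them only; others in the source may bear on it.

Compound 1 `Nc1ccc(-c2nc3cc(F)ccc3s2)cc1` gives 29500 nM in a functional assay on OVCAR-5 cells (Homo sapiens) for inhibition (a lower number here means a stronger inhibitor of growth, a higher number a weaker inhibitor of growth), as a measured number
Compound 2 `Cc1cc(-c2nc3cc(F)c(F)cc3s2)ccc1N` gives > 100000 nM as a limit
Compound 3 `Cc1cc(-c2nc3ccc(F)cc3s2)ccc1N` gives > 100000 nM as a limit

For the measured compounds named here, compound 1 holds the only number, and all else is the limit of > 100000 nM in this assay, at which 2 of the 3 values shown sit, and no more. Compound 4 `Nc1ccc(-c2nc3cc(F)ccc3s2)cc1Br` arises from compound 1 by bromo in place of hydrogen on an aromatic carbon in the form of bromo in place of hydrogen on an aromatic carbon, ortho to an amino group. Going by the values given here, the one measured step is a step that the two limits leave unreadable from compound 2 to compound 3 and offers no size to carry over. The expectation therefore rests on compound 1 at 29500 nM alone, with a modest weakening in this assay as the cautious guess. The expected step is a 1.4-fold higher number from compound 1 to compound 4 (0.13 log units; within the scatter) in this rough estimate. Compound 4 is estimated at 40000 nM with an expected range from 10000 nM to 100000 nM for now.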

Compound 4, concentration for 50% growth inhibition: 50 nM
Estimate against measurement, compound 4: 800-fold (2.90 log units) above; measured number outside the range, below it.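

In this assay, for the compounds shown here, this aromatic carbon ortho to an amino group proves highly sensitive on the core of compound 1: bromo in place of hydrogen, a change of 1 heavy atom, gives a 590-fold lower number from compound 1 to compound 4 (2.77 log units; beyond the scatter), the only readable step. Compound 2 and compound 3 remain at a limit, and the step between them cannot be read: the limit of > 100000 nM in this assay, at which 2 of the 4 values shown sit.

As far as these compounds go, it remains open whether chloro or iodo at this position would give a comparable step, and whether bromo would have the same effect with the fluoro groups of compound 2 or compound 3. The compounds shown do not explain the step.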